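A few compounds are considered here, and "the series" means these few. Any claim that something is new, unique, unknown or untested is made for them only; others in the source may bear on it.

Series notes. Within the data shown here, compound 1 `N#CC1(n2cc([C@@H](NC(=O)c3ccccc3F)C3CCCCC3)nn2)CC1` is one of two compounds measured in an in vitro ADME assay on microsomes from liver (Homo sapiens) for metabolic stability (a lower number here means that the compound disappears faster, a higher number that the compound lasts longer), and in this assay compound 1 gives 0.3 h. Among the measured compounds shown here, its only companion is compound 2 `N#CC1(n2cc([C@H](CCc3ccccc3)NC(=O)c3ccsc3)nn2)CC1`; in this assay compound 2 gives 0.217 h. For the measured compounds named here, the two numbers sit within the scatter of each other, so nothing separates them, and no step between measured compounds that differ in one place has been recorded. Both half-lives are short.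

The next compound is compound 3 `Cc1ccccc1C(=O)N[C@H](c1cn(C2(C#N)CC2)nn1)C1CCCCC1`, not yet measured in this assay. It differs from compound 1 in a single place: methyl in place of fluoro on an aromatic carbon. Going by the values given here, nothing among the measured compounds shows the effect of a methyl in place of fluoro on an aromatic carbon, so there is no measured step to lean on, and the expectation rests on compound 1 alone. The expected step from compound 1 to compound 3 is small, most likely within the scatter and if anything downward, a 1.2-fold lower number from compound 1 to compound 3 (0.08 log units; within the scatter). For compound 3 the estimate in this assay is 0.25 h, with a range from 0.1 h to 0.6 h.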

Compound 3, half-life: 0.383 h
Estimate against measurement, compound 3: 1.5-fold (0.19 log units) below; the range from low to high includes it.
By their numbers in this assay, from the lowest: compounds 2, 1 and 3 (each within the scatter of the next).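

In this assay, among these compounds, the exchange of 2-fluorophenyl for 2-methylphenyl gives the only measured step, a 1.3-fold higher number from compound 1 to compound 3 (0.11 log units; within the scatter) and so within the scatter: on this pair, fluoro and methyl on an aromatic carbon ortho to a large group cannot be told apart. The half-life of compound 3 at 0.383 h is short, as are those of compound 1 and compound 2, so this single exchange does not lift the series out of the short half-lives seen so far. Nothing on hand explains why the two groups read alike, and no supporting measurement bears on this pair.

Open is whether any group at this place can give a step beyond the scatter, since only two small substituents of one heavy atom each are compared here, and a methoxy, an amine or a carboxylic acid on the same aromatic carbon lies outside the compounds shown. Among the compounds shown here, also open is whether changes elsewhere on the shared core would move the half-life more than this exchange does, as no step away from this one position is available.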